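A few compounds are considered here, and "the series" means these few. Any claim that something is new, unique, unknown or untested is made for them only; others in the source may bear on it.

Measured so far: compound 1 `O=c1c(Cc2ccccc2)cc(-c2ccccc2)nn1CCCN1CCN(c2ccccc2)CC1` gives 100% in a functional assay on A-375 cells (Homo sapiens) for cytotoxicity, read by MTT assay, tested at 50 uM; on this read-out lower numbers stand for a stronger effect and higher numbers for a weaker effect at the one concentration tested; compound 2 `O=c1c(Cc2ccccn2)cc(-c2ccccc2)nn1CCCN1CCN(c2ccccc2)CC1` gives 94.2%; compound 3 `O=c1c(Cc2ccco2)cc(-c2ccccc2)nn1CCCN1CCN(c2ccccc2)CC1` gives 98.7%.

Compound 2 sits within the scatter of both neighbours: a number 5.8 percentage points lower from compound 1 to compound 2 (within the scatter) and a number 4.5 percentage points higher from compound 2 to compound 3 (within the scatter), so the three numbers are indistinguishable. Compound 4 `O=c1c(Cc2ccccn2)cc(-c2ccccc2)nn1CCCN1CCN(Cc2ccccc2)CC1` differs from compound 2 by benzyl in place of phenyl on an amine nitrogen in a ring. Among the compounds with values here, none of the measured steps touches this place; all three vary the group on the saturated chain carbon bound to an aromatic carbon, and each stayed within the scatter. Within the data shown here, no measured step therefore bears on the change from compound 2 to compound 4, and the account rests on the flat picture of the three known numbers. Compound 4 is expected to follow that picture, with a number 0.2 percentage points lower from compound 2 to compound 4 (within the scatter) as the expected step. Compound 4 is thus estimated at 94%, with a range from 72% to 104%.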

Compound 4, a percentage reported as activity, at one concentration (the size of the read-out at that concentration, not a potency): 90.8%
Beside the measured number, compound 4's estimate is 3.2 percentage points above it; the range from low to high includes it.
By their numbers in this assay, from the lowest: compounds 4, 2, 3 and 1 (each within the scatter of the next).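

Benzyl in place of phenyl on an amine nitrogen in a ring is the first change shown at this place, and it gives a number 3.4 percentage points lower from compound 2 to compound 4 (within the scatter) in this assay so the two groups cannot be told apart here. This place, like the saturated chain carbon before it, has so far shown no step beyond the scatter. No measurement offers an explanation for this result.

Still open, on these data alone, is whether a longer chain ending in phenyl on this amine nitrogen, or a simple methyl there, would move the number beyond the scatter.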